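The source may report more compounds than this note shows. Statements on the series, on what has been measured and on what is new or still open speak of the compounds shown alone.

Compounds measured in a functional assay on cells (Leukemia cell, Homo sapiens) for cytotoxicity, with a stated time of 48 h; on this read-out lower numbers stand for stronger inhibition of growth and higher numbers for weaker inhibition of growth:
compound 1 `O=C1Nc2ccccc2/C1=C\c1c(Cl)n(Cc2ccccc2)c2ccccc12` gives 21400 nM
compound 2 `O=C1Nc2ccccc2/C1=C\c1c(Cl)n(CCCc2ccccc2)c2ccccc12` gives 50100 nM
compound 3 `COc1cc2c(c(OC)c1OC)/C(=C\c1c(Cl)[nH]c3ccccc13)C(=O)N2` gives 7080 nM

Compound 2 stands highest of the three; compound 1 lies nearest, and the step of a 2.3-fold higher number from compound 1 to compound 2 (0.37 log units; beyond the scatter) shows how the phenethyl in place of phenyl on a saturated chain carbon bound to an aromatic nitrogen raised the number. Compound 3 gives the lowest value of the set, but it differs from compound 2 in more than one place, so its two values show only the gap, not a step.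

Compound 4 `O=C1Nc2ccc(Cl)cc2/C1=C\c1c(Cl)n(CCCc2ccccc2)c2ccccc12` differs from compound 2 by chloro in place of hydrogen on an aromatic carbon. For the measured compounds named here, no measured step touches the ring where the chloro enters, so nothing here speaks for a large change in this assay in either direction. Compound 4 is therefore expected to sit near compound 2, with the step of a 1.4-fold lower number from compound 2 to compound 4 (0.16 log units; within the scatter) likely within the scatter, and its estimated value is 35000 nM, between 15000 nM and 90000 nM.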

Compound 4, concentration for total growth inhibition: 81300 nM
The estimate for compound 4 lay 2.3-fold (0.37 log units) below the measured number; measured number inside the range.
By their numbers in this assay, from the lowest: compound 3; then compound 1; then compounds 2 and 4 (each within the scatter of the next).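

With the chain on the aromatic nitrogen kept, chloro in place of hydrogen on this aromatic carbon gives a 1.6-fold higher number from compound 2 to compound 4 (0.21 log units; within the scatter) in this assay. For the compounds shown here, this is the first measured change on this ring of the shared core, and it does not separate compound 2 from compound 4. Nothing available explains this result. Still open, going by these compounds, is whether an amine or a carboxylic acid on this same carbon would give a step beyond the scatter, and whether chloro here would give a similar result with the chain of compound 1.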